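This account rests on a few compounds, and the source may have more. Where it says the series, first, only, none or still open, it means among the compounds named here.

Going by the values given here, compound 1 `Oc1ccc2[nH]ncc2c1C(c1ccc(-n2cccc2)cc1)N1CCCCC1` and compound 2 `Cc1ccc(C(Nc2ccccn2)c2ccc3cccnc3c2O)cc1` are the two measured members of this set. In an assay for inhibition of protein disulfide-isomerase (Homo sapiens), with a stated time of 1 h (a lower number here means a stronger inhibitor, a higher number a weaker inhibitor), compound 1 gives 290 nM, the lower of the two numbers. In this assay compound 2 gives 460 nM. Among the compounds with values here, the gap between these two numbers lies within the scatter, so neither compound can be called the stronger inhibitor, and the two structures differ in more than one place, so no single-point step between them is available. Compound 3 `Oc1ccc2[nH]ncc2c1C(c1ccc(-c2cncnc2)cc1)N1CCCCC1` has not yet been measured. It differs from compound 1 in one place: pyrimidin-5-yl in place of 1H-pyrrol-1-yl on an aromatic carbon. Within the data shown here, no measured pair covers an exchange of this kind, so the direction is open. The expected step of a 1.2-fold higher number from compound 1 to compound 3 (0.08 log units; within the scatter) is put at none beyond the scatter, with a range wide enough to allow a move either way. For compound 3 in this assay the estimate is 350 nM, between 120 nM and 1000 nM.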

Compound 3, half-maximal inhibitory concentration: 830 nM
Compound 3: middle estimate off by 2.4-fold (0.38 log units), on the low side; the measured number falls inside the stated range.
By their numbers in this assay, from the lowest: compounds 1, 2 and 3 (each within the scatter of the next, the first and the last beyond it).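

Going by these compounds alone, the group on an aromatic carbon of a six-membered aromatic ring of carbon only, para to a large group, responds to exchange: in this assay, pyrimidin-5-yl in place of 1H-pyrrol-1-yl gives a 2.9-fold higher number from compound 1 to compound 3 (0.46 log units; beyond the scatter) as the first single-place step. The change is modest, and compound 3 still gives 830 nM with the six-membered aromatic ring in this place. No supporting measurement speaks to the origin of this step.

Open, from the compounds shown here alone, is whether ring size or the count of ring nitrogens carries the step, which a phenyl or pyridin-3-yl group on this carbon would separate. Also open, going by these compounds, is whether an amine or a carboxylic acid here would move the number in either direction, and whether the same exchange behaves alike on the core of compound 2.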